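Bromo to trifluoromethyl in two arrangements of the core

The source may report more compounds than this note shows. Statements on the series, on what has been measured and on what is new or still open speak of the compounds shown alone.

Compound 1 `COc1cc(Cl)ccc1C(=O)Nc1ccc(Br)cc1O` is the starting point; in a functional assay on HepG2 cells (Homo sapiens) for cytotoxicity, with a stated time of 24 h (on this read-out lower numbers stand for stronger inhibition and higher numbers for weaker inhibition), compound 1 gives 46600 nM. Compound 3 `COc1cc(Cl)ccc1C(=O)Nc1ccc(C(F)(F)F)cc1O` differs from compound 1 by trifluoromethyl in place of bromo on an aromatic carbon and in this assay compound 3 gives 3900 nM, so that a 12-fold lower number from compound 1 to compound 3 (1.08 log units; beyond the scatter). Compound 2 `COc1cc(Cl)ccc1C(=O)Nc1cc(Br)ccc1O` has the same atoms as compound 1, joined differently; the difference between the two cores is not broken down here. In this assay compound 2 gives 5630 nM, a number within the scatter of compound 3, while compound 1 stands beyond the scatter with the highest number of the three.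

Compound 4 `COc1cc(Cl)ccc1C(=O)Nc1cc(C(F)(F)F)ccc1O` is not yet measured. It differs from compound 2 by trifluoromethyl in place of bromo on an aromatic carbon. The surroundings of the place are not the same as in the pair compound 1 and compound 3: there the carbon is meta to a hydroxy group and para to a large group, here it is meta to a large group and para to a hydroxy group, so this is the same kind of change, not the same change. Among the compounds with values here, only one measured instance exists. A lower number for compound 4 than for compound 2 is expected, but a smaller step than the earlier one, because a 12-fold lower number from compound 1 to compound 3 (1.08 log units; beyond the scatter) sets out from the high number of compound 1, whereas compound 2 already lies near compound 3. The expected step for compound 4 is a 3.1-fold lower number from compound 2 to compound 4 (0.50 log units; beyond the scatter). Compound 4 is estimated at 1800 nM, expected to fall between 600 nM and 6000 nM in this assay.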

Compound 4, half-maximal inhibitory concentration: 25400 nM
Compound 4: the middle estimate sits 14-fold (1.15 log units) below what was measured; the measured number lies above the stated range.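

Trifluoromethyl in place of bromo on an aromatic carbon gives a 4.5-fold higher number from compound 2 to compound 4 (0.65 log units; beyond the scatter) in this assay and so runs in opposite directions on the two cores: the same change on two cores in this assay, a 12-fold lower number (1.08 log units; beyond the scatter) from compound 1 to compound 3 and a 4.5-fold higher number (0.65 log units; beyond the scatter) from compound 2 to compound 4, 54-fold (1.73 log units) apart, beyond the scatter of two such steps.

Within these four compounds, the step measured on one core therefore gives no safe guide to the size or even the direction of the step on the other, and this change cannot be treated as transferable between the two arrangements. What this does not show is the reason for the reversal: there is one pair on each core, the difference between the cores is not broken down, and neither pair says how any other replacement of bromo would behave.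

Left open is whether the reversal is confined to bromo and trifluoromethyl or would also appear with another group on the same carbon, such as a nitrile or an amine. Also open, from the compounds shown here alone, is what a methoxy group in place of the hydroxy group would do to the two steps in this assay on either core.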